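A few compounds are considered here, and "the series" means these few. Any claim that something is new, unique, unknown or untested is made for them only; others in the source may bear on it.

Measured compounds:
- compound 1 `Cc1c(Cl)ccc(S(=O)(=O)N(C)CCOCC(=O)N(C)Cc2ccc(C3=NCCN3)cc2)c1Cl`: 9.1
- compound 2 `Cc1c(Cl)cccc1S(=O)(=O)N(C)CCOCC(=O)N(C)Cc1ccc(C2=NCCN2)cc1`: 8

In a functional assay on Umbilical vein for antagonist activity at B1 bradykinin receptor (Homo sapiens), using Schild analysis, with a stated time of 30 min (on this read-out lower numbers stand for lower potency and higher numbers for higher potency (the scale is a negative logarithm)), compound 1 gives 9.1 and compound 2 gives 8. For the measured compounds named here, compound 2 stands lowest of the two numbers; its only neighbour is compound 1, and the step of a number 1.10 log units lower from compound 1 to compound 2 (beyond the scatter) marks that gap as beyond the usual scatter.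

Compound 3 `CN(Cc1ccc(C2=NCCN2)cc1)C(=O)COCCN(C)S(=O)(=O)c1ccccc1C(F)(F)F` has not been measured. It differs from compound 2 in one place: 2-(trifluoromethyl)phenyl in place of 3-chloro-2-methylphenyl on a sulfonyl sulfur. Going by the values given here, the only measured step, a number 1.10 log units lower from compound 1 to compound 2 (beyond the scatter), also changed the aryl group on the sulfonyl sulfur, and it was large. Yet that step removed a chloro and moved a methyl, whereas the present change swaps a chloro-methyl pattern for a single trifluoromethyl, so it does not tell directly what to expect. With no closer comparison, the step of no change at the digits printed from compound 2 to compound 3 (within the scatter) is expected to be small, and the estimate for compound 3 in this assay is 8, with a range from 7.2 to 8.8.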

Compound 3, negative logarithm of the antagonist equilibrium constant: 9.2
Compound 3: the middle estimate sits 1.20 log units below what was measured, and the stated range ends below it.
By their numbers in this assay, from the lowest: compound 2; then compounds 1 and 3 (each within the scatter of the next).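

In this assay, the aryl group on the sulfonyl sulfur again has a large influence: placing 2-(trifluoromethyl)phenyl there in place of 3-chloro-2-methylphenyl gives a number 1.20 log units higher from compound 2 to compound 3 (beyond the scatter), so the low value of compound 2 does not mark a limit for this place on the molecule. The other comparison gives a number 0.10 log units higher from compound 1 to compound 3 (within the scatter), which shows that two differently substituted aryl groups, 2-(trifluoromethyl)phenyl and 2,4-dichloro-3-methylphenyl, can give values that cannot be told apart in this read-out, and that the 2,4-dichloro-3-methylphenyl pattern is not the only one that reaches this level. Nothing measured here explains why these aryl groups differ as they do.

The three compounds cannot separate the contribution of the trifluoromethyl group from that of the aryl ring as a whole, and they do not show how a plain phenyl, a 2-methylphenyl or a 2-chlorophenyl would compare on the same sulfonyl sulfur. Also open, on these data alone, is whether a 2-methoxyphenyl or a pyridine ring at this place would hold the value seen for compound 3 or fall back towards that of compound 2.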